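A few compounds are considered here, and "the series" means these few. Any claim that something is new, unique, unknown or untested is made for them only; others in the source may bear on it.

Compound 1 `O=C(N/N=C/c1ccccc1)c1cnccn1` is the parent of this small set. Within the data shown here, in an ADME assay on J774 cells (Mus musculus) for cytotoxicity, read by MTT assay, with a stated time of 48 h, tested at 50 ug/mL (a higher number here means a weaker effect of the compound at the concentration tested, a lower number a stronger effect), compound 1 gives 100%, the highest of the three numbers measured so far. Two compounds differ from it in a single place. Compound 2 `COc1ccc(/C=N/NC(=O)c2cnccn2)cc1` carries a methoxy in place of hydrogen on an aromatic carbon and gives 74%; a number 26 percentage points lower from compound 1 to compound 2 (beyond the scatter). Compound 3 `N#Cc1ccccc1/C=N/NC(=O)c1cnccn1` carries a cyano in place of hydrogen on an aromatic carbon and gives 92%; a number 8 percentage points lower from compound 1 to compound 3 (within the scatter). The unmeasured compound 4 `O=C(N/N=C/c1cccc([N+](=O)[O-])c1)c1cnccn1` differs from compound 1 as follows: nitro in place of hydrogen on an aromatic carbon. Both measured steps bear on this change, since each also puts a new group on an aromatic carbon of the shared core; one step was modest and beyond the scatter, the other stayed within it. For compound 4 a small step downward, if any, is therefore expected, a number 12 percentage points lower from compound 1 to compound 4 (beyond the scatter). Compound 4 is thus estimated to give 88%, within a range from 65% to 100%.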

Compound 4, a percentage reported as activity, at one concentration (the size of the read-out at that concentration, not a potency): 100%
Compound 4: the middle estimate sits 12 percentage points below what was measured; the measured number falls inside the stated range.
By their numbers in this assay, from the lowest: compound 2; then compounds 3, 1 and 4 (each within the scatter of the next).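

In this assay, the nitro change shows no change at the digits printed from compound 1 to compound 4 (within the scatter), so at this place on the ring, meta to a large group, nitro in place of hydrogen leaves the read-out unmoved. Putting a new group on an aromatic carbon of the shared core therefore does not by itself lower the number: this step stands with a number 8 percentage points lower from compound 1 to compound 3 (within the scatter), and only the methoxy step, a number 26 percentage points lower from compound 1 to compound 2 (beyond the scatter), lies beyond the scatter. Nothing measured here accounts for why the methoxy step differs from the other two.

Going by these compounds, whether nitro would behave the same on another carbon of that ring stays open, as does the effect of an amine or a carboxylic acid at this place. On these data alone, with a read-out at one concentration, how compound 4 behaves at other concentrations also stays open.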